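Hepatic Extraction of Three Aryl Furan Amides and a Fourth

This account rests on a few compounds, and the source may have more. Where it says the series, first, only, none or still open, it means among the compounds named here.

Compound 1 `CC(=O)N1CCC(n2cc(-c3cnc(N)c4oc(-c5cccc6ccccc56)cc34)cn2)CC1` in an ADME assay on microsomes from liver (Homo sapiens) for metabolic stability (on this read-out lower numbers stand for lower hepatic extraction and higher numbers for higher hepatic extraction), gives 0.66. Compound 2 `CC(=O)N1CCC(n2cc(-c3cnc(N)c4oc(-c5cccc6nnsc56)cc34)cn2)CC1` in this assay gives 0.68. Compound 3 `CC(=O)N1CCC(n2cc(-c3cnc(N)c4oc(-c5cccc6cnsc56)cc34)cn2)CC1` in this assay gives 0.73.

Compound 3 holds the highest of the three numbers, though its nearest neighbour, compound 2, sits only a number 0.050 higher from compound 2 to compound 3 (within the scatter), and the furthest, compound 1, only a number 0.070 higher from compound 1 to compound 3 (within the scatter). Compound 4 `CC(=O)N1CCC(n2cc(-c3cnc(N)c4oc(-c5cn(C)c6cnccc56)cc34)cn2)CC1` differs from compound 3 in one place: a group of 10 heavy atoms (8 carbon, 2 nitrogen; one five-membered aromatic ring with 1 hetero atom, one six-membered aromatic ring with 1 hetero atom) in place of a group of 9 heavy atoms (7 carbon, 1 nitrogen, 1 sulfur; one five-membered aromatic ring with 2 hetero atoms, one six-membered aromatic ring of carbon only), on an aromatic carbon.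

Within the data shown here, the steps that bear on this change are those exchanging one bicyclic aryl group for another on the same carbon, a number 0.020 higher from compound 1 to compound 2 (within the scatter) and a number 0.070 higher from compound 1 to compound 3 (within the scatter), both within the scatter. A step of similar size, with no clear direction beyond the scatter, is therefore expected, namely a number 0.050 lower from compound 3 to compound 4 (within the scatter). Compound 4 is estimated at 0.68, within the range 0.55 to 0.8.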

Compound 4, hepatic extraction ratio: 0.64
Estimate against measurement, compound 4: 0.040 above; measured number inside the range.
By their numbers in this assay, from the lowest: compounds 4, 1, 2 and 3 (each within the scatter of the next).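

Compound 4 is the first shown with a hetero atom in the six-membered aromatic ring of the group on this carbon, next to the ring oxygen, and this assay still shows no step beyond the scatter: a number 0.090 lower from compound 3 to compound 4 (within the scatter), a number 0.040 lower from compound 2 to compound 4 (within the scatter) and a number 0.020 lower from compound 1 to compound 4 (within the scatter). So these four bicyclic groups, with or without sulfur, do not separate at this position. Nothing available accounts for the small differences among them.

From the compounds shown here alone, it remains open whether a single phenyl ring or a saturated amine such as morpholine on this carbon would move the number beyond the scatter.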